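Benzothiazole amides: toward a urea at the carbonyl

A few compounds are considered here, and "the series" means these few. Any claim that something is new, unique, unknown or untested is made for them only; others in the source may bear on it.

Compounds measured so far:
compound 1, `O=C(Nc1ccc2nc(NC(=O)C3CCCCC3)sc2c1)c1ccccc1Cl`, 0.025 ug/mL
compound 2, `O=C(Nc1ccc2nc(NC(=O)C3CCCCC3)sc2c1)c1cccnc1Cl`, 0.075 ug/mL

Both compounds were tested in a functional assay on WI-38 VA13 cells (Homo sapiens) for cytotoxicity; on this read-out lower numbers stand for an effect already at smaller amounts and higher numbers for an effect only at larger amounts of compound. Going by the values given here, compound 1 gives 0.025 ug/mL, and compound 2 gives 0.075 ug/mL, so compound 2 stands at the higher of the two numbers; the single step that connects them, a 3.0-fold higher number from compound 1 to compound 2 (0.48 log units; beyond the scatter), lies beyond the scatter.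

The unmeasured compound 3, `Cc1cccc(C)c1NC(=O)Nc1ccc2nc(NC(=O)C3CCCCC3)sc2c1`, differs from compound 2 by (2,6-dimethylphenyl)amino in place of 2-chloropyridin-3-yl on a carbonyl carbon. Among the compounds with values here, the only measured step swaps one aromatic ring for another on the same carbonyl carbon and gives a modest change, a 3.0-fold higher number from compound 1 to compound 2 (0.48 log units; beyond the scatter). Here the ring changes and a further nitrogen enters, so that measured step is only a loose guide. Given the modest size of a 3.0-fold higher number from compound 1 to compound 2 (0.48 log units; beyond the scatter), the step for compound 3 is expected to be of similar order, with a small loss more likely than a gain, a 1.6-fold higher number from compound 2 to compound 3 (0.20 log units; within the scatter). For compound 3 in this assay the estimated value is 0.12 ug/mL, with a likely range from 0.025 ug/mL to 0.6 ug/mL.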

Compound 3, half-maximal effective concentration: 0.56 ug/mL
The estimate for compound 3 lay 4.7-fold (0.67 log units) below the measured number; low and high end bracket the measured number.
By their numbers in this assay, from the lowest: compound 1; then compound 2; then compound 3.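

Placing (2,6-dimethylphenyl)amino on the carbonyl carbon gives the highest number so far in this assay: the change brings a 7.5-fold higher number from compound 2 to compound 3 (0.87 log units; beyond the scatter), and measured against the chlorinated benzene ring it brings a 22-fold higher number from compound 1 to compound 3 (1.35 log units; beyond the scatter). The earlier exchange of one aromatic ring for another, a 3.0-fold higher number from compound 1 to compound 2 (0.48 log units; beyond the scatter), was modest, whereas the longer path to the urea is large, so this position responds more strongly when a nitrogen carrying a hydrogen-bond donor and a methyl-bearing ring enter together than the first pair alone could show. No measurement here explains this shift.

The change alters the link and the ring at once, so the compounds shown cannot divide the rise between the urea nitrogen and the methyl groups. As far as these compounds go, a plain phenylamino or a 2-chlorophenylamino group on the same carbonyl carbon would address that division, and it also remains open whether an aliphatic amine such as piperidine at this place would follow the same direction.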